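The source may report more compounds than this note shows. Statements on the series, on what has been measured and on what is new or still open speak of the compounds shown alone.

Values measured so far in a functional assay on SK-N-AS cells (Homo sapiens) for antiproliferative activity, with a stated time of 72 h; a higher number here means a weaker inhibitor, a lower number a stronger inhibitor:
- compound 1 `Cc1ccc(NC(=O)CCN(Cc2ccc(C(=O)NO)cc2)C(=O)c2cc(C)cc(C)c2)cc1` - 220 nM
- compound 2 `O=C(CCN(Cc1ccc(C(=O)NO)cc1)C(=O)c1ccccc1)NCc1ccccc1` - 3310 nM
- compound 3 `COc1cc(OC)cc(C(=O)N(CCC(=O)NCc2ccccc2)Cc2ccc(C(=O)NO)cc2)c1` - 9470 nM

Compound 2, at 3310 nM, sits in the middle of these three values, with compound 1 lower and compound 3 higher. The next compound to consider is compound 4 `Cc1ccc(NC(=O)CCN(Cc2ccc(C(=O)NO)cc2)C(=O)c2ccccc2)cc1`, which has 4-methylphenyl in place of benzyl on an amide-type nitrogen.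

No measured single change matches this one. For the measured compounds named here, the only such step is a 2.9-fold higher number from compound 2 to compound 3 (0.46 log units; beyond the scatter). It is modest, but it lies at a different place, on a carbonyl carbon, so it says little here.

The closest evidence is compound 1, which carries the same 4-methylphenyl group and reads 220 nM, well below compound 2. However, compound 1 also differs from compound 2 on the other carbonyl, so only part of that gap is expected to carry over to compound 4.

A clear step towards a lower number is therefore expected in this assay, with the estimate being a 4.7-fold lower number from compound 2 to compound 4 (0.67 log units; beyond the scatter). For compound 4 the estimated value is 700 nM, with an expected range from 200 nM to 2500 nM.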

Compound 4, half-maximal inhibitory concentration: 620 nM
For compound 4 the middle estimate is 1.1-fold (0.05 log units) above the measured one, within the range that was stated.
By their numbers in this assay, from the lowest: compound 1; then compound 4; then compound 2; then compound 3.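

In this assay benzyl and 4-methylphenyl on the amide-type nitrogen have the same count of heavy atoms, yet the swap alone gives a 5.3-fold lower number from compound 2 to compound 4 (0.73 log units; beyond the scatter) and so shows that this position matters without any change on the other carbonyl. Compound 4 also isolates the carbonyl side with 4-methylphenyl held fixed, and replacing 3,5-dimethylphenyl with phenyl gives a 2.8-fold higher number from compound 1 to compound 4 (0.45 log units; beyond the scatter) as a separate contribution to the low value of compound 1. Nothing measured here explains why either change moves the number.

As far as these compounds go, it remains open whether the gain depends on the methyl group, which plain phenyl on that nitrogen would test, or on the missing carbon link of benzyl, which a longer chain such as 2-phenylethyl would probe. A 4-methoxyphenyl or a pyridinyl ring at this place would show how far the trend extends.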